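The compounds below may be only part of what the source reports. "The series", "measured", "known", "first", "only" and "open" are said of these compounds alone.

Compound 1 `NC[C@@H]1CCCc2cc(S(=O)(=O)c3cn[nH]c3)ccc21`: in an assay on isolated protein for displacement of a labelled ligand from 5-hydroxytryptamine receptor 6 (Homo sapiens) (on this read-out lower numbers stand for stronger inhibition and higher numbers for weaker inhibition), compound 1 gives 2 nM.
Compound 2 `CN(C)S(=O)(=O)NC[C@@H]1CCCc2cc(S(=O)(=O)c3cccc(F)c3)ccc21`: in this assay compound 2 gives 2 nM.

Compound 2 stands level with compound 1 at the digits shown; the two values lie within the usual scatter of this assay, so nothing separates them. Among the compounds with values here, no step between measured compounds that differ in one place is available, so the two values give no guide to how a change on the amine nitrogen shifts the read-out.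

Compound 3 `CNC(=O)NC[C@@H]1CCCc2cc(S(=O)(=O)c3cccc(F)c3)ccc21` is the next compound to be measured. It differs from compound 2 in one place: methylcarbamoyl in place of dimethylsulfamoyl on an amine nitrogen. Both groups are small and sit on the same amine nitrogen, so the step from compound 2 to compound 3 is expected to be small, with a slight drift toward weaker inhibition that may not exceed the scatter, an expected 2.0-fold higher number from compound 2 to compound 3 (0.30 log units; within the scatter). Compound 3 is therefore estimated at 4 nM, within a range from 1.5 nM to 12 nM.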

Compound 3, inhibition constant: 0.398 nM
Beside the measured number, compound 3's estimate is 10-fold (1.00 log units) above it, and the stated range ends above it.
By their numbers in this assay, from the lowest: compound 3; then compounds 1 and 2 (each within the scatter of the next).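

Within the data shown here, changing dimethylsulfamoyl to methylcarbamoyl on this amine nitrogen gives the first step here that can be read on its own: in this assay it is a 5.0-fold lower number from compound 2 to compound 3 (0.70 log units; beyond the scatter) and, though modest, it lies beyond the scatter. The group on this nitrogen therefore affects the read-out, and the entering group, which has fewer heavy atoms and brings a hydrogen-bond donor, gives the lower number. Nothing available here explains why the number falls.

A single step cannot show which of the differences between these two groups accounts for the shift, or whether the same shift would appear on another core. Acetyl, ethylcarbamoyl or methanesulfonyl on the same nitrogen would help to separate those differences.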